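The source may hold more compounds than are shown below. What is called first, only, known or untested is meant among the compounds shown, and "the series" means these compounds.

Within the data shown here, compound 1 `COc1ccc(-c2cc(C(=O)/C=C/c3ccccc3)nc3cc(-c4ccccc4)nn23)cc1OC` gives 18600 nM in a functional assay on A549 cells (Homo sapiens) for antiproliferative activity, read by MTT assay, with a stated time of 24 h (on this read-out higher numbers stand for weaker inhibition and lower numbers for stronger inhibition), the higher of the two numbers so far. Compound 2 `COc1ccc(C(=O)/C=C/c2cc(-c3ccc(OC)cc3)n3nc(-c4ccccc4)cc3n2)cc1` gives 2900 nM in this assay, a gap beyond the usual scatter; the two differ at several places, so that gap is not tied to any single change. Compound 3 `COc1ccc(-c2cc(/C=C/C(=O)c3ccccc3)nc3cc(-c4ccccc4)nn23)cc1OC` is the single-step neighbour of compound 1: 2-benzoylethenyl in place of (2-phenylethenyl)carbonyl on an aromatic carbon. Among the measured compounds shown here, no measured pair shows this change, so the step is expected to stay near the scatter, a 1.6-fold lower number from compound 1 to compound 3 (0.19 log units; within the scatter), with no confident direction. On that basis compound 3 is estimated at 12000 nM, in the range 4000 nM to 40000 nM.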

Compound 3, half-maximal inhibitory concentration: 10700 nM
Beside the measured number, compound 3's estimate is 1.1-fold (0.05 log units) above it; the range from low to high includes it.
By their numbers in this assay, from the lowest: compound 2; then compounds 3 and 1 (each within the scatter of the next).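

Moving the carbonyl by placing 2-benzoylethenyl in place of (2-phenylethenyl)carbonyl on this aromatic carbon, next to the ring nitrogen, gives a 1.7-fold lower number from compound 1 to compound 3 (0.24 log units; within the scatter) in this assay. At this position, the read-out therefore does not separate these two arrangements of the same atoms. Nothing available explains this result.

As far as these compounds go, it remains open whether an amine or a carboxylic acid on the benzoyl ring, or a longer chain in place of the ethenyl link, would give a step beyond the scatter. The same exchange on the core of compound 2 is also unresolved.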